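A few compounds are considered here, and "the series" means these few. Any claim that something is new, unique, unknown or untested is made for them only; others in the source may bear on it.

Measured so far in a functional assay on HCT-116 cells (Homo sapiens) for cytotoxicity, read by MTT assay; a higher number here means a weaker inhibitor, a lower number a stronger inhibitor:
- compound 1 `CCn1cc(C(=O)Nc2ccccc2O)c(=O)c2cc(F)c(N3CCNC(C)C3)c(F)c21`: 5370 nM
- compound 2 `CCn1cc(C(=O)Nc2cc([N+](=O)[O-])ccc2F)c(=O)c2cc(F)c(N3CCNC(C)C3)c(F)c21`: 2600 nM

Compound 2 has the lower of the two numbers, at 2600 nM. Compound 3 `CCn1cc(C(=O)NCc2ccc(OC)cc2)c(=O)c2cc(F)c(N3CCNC(C)C3)c(F)c21` has 4-methoxybenzyl in place of 2-fluoro-5-nitrophenyl on an amide-type nitrogen.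

Within the data shown here, one measured step bears on this change, at the same nitrogen: a 2.1-fold lower number from compound 1 to compound 2 (0.32 log units; beyond the scatter). It is modest, and it replaces 2-hydroxyphenyl with 2-fluoro-5-nitrophenyl. Among the measured compounds shown here, no measured compound carries 4-methoxybenzyl, so this step offers only a rough guide to size. Since compound 2 sits at the low end at 2600 nM, a modest move to a higher number in this assay is expected, close to the scatter. The expected step is a 1.5-fold higher number from compound 2 to compound 3 (0.19 log units; within the scatter). For compound 3 the estimated value is 4000 nM, with an expected range of 1500 nM to 11000 nM.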

Compound 3, half-maximal inhibitory concentration: 1400 nM
Compound 3: the middle estimate sits 2.9-fold (0.46 log units) above what was measured; the measured number lies below the stated range.
By their numbers in this assay, from the lowest: compounds 3 and 2 (each within the scatter of the next); then compound 1.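

In this assay, the amide-type nitrogen accepts 4-methoxybenzyl, which carries neither the nitro group nor the fluorine of 2-fluoro-5-nitrophenyl, with a 1.9-fold lower number from compound 2 to compound 3 (0.27 log units; within the scatter). The two groups therefore cannot be separated in this assay, so a 2-fluoro-5-nitrophenyl group is not needed to keep the number at this level. Against 2-hydroxyphenyl the change is clearer but still modest, with a 3.8-fold lower number from compound 1 to compound 3 (0.58 log units; beyond the scatter), so both replacements of 2-hydroxyphenyl in this small set give lower numbers.

Nothing available explains these differences. From the compounds shown here alone, it remains open how an unsubstituted benzyl, a longer chain such as 2-phenylethyl, or a group with no ring, such as a simple alkyl chain, would read at this nitrogen, and whether the methoxy group contributes at all.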